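This account rests on a few compounds, and the source may have more. Where it says the series, first, only, none or still open, it means among the compounds named here.

Compound 1 `CCOc1ccc(NC(=O)Nc2cccc(CNc3nccnc3Cl)c2)cc1` gives 7240 nM in a functional assay on MGC-803 cells (Homo sapiens) for antiproliferative activity, read by MTT assay, with a stated time of 48 h (a higher number here means a weaker inhibitor, a lower number a stronger inhibitor), the second highest of the three numbers measured. Compound 2 `O=C(Nc1ccc(Cl)cc1)Nc1cccc(CNc2nccnc2Cl)c1` gives 4980 nM in this assay, and compound 3 `Cc1ccccc1NC(=O)Nc1cccc(CNc2nccnc2Cl)c1` gives 14000 nM. Compound 4 `Cc1ccc(NC(=O)Nc2cccc(CNc3nccnc3Cl)c2)cc1` differs from compound 1 in one place: methyl in place of ethoxy on an aromatic carbon. For the measured compounds named here, two measured steps bear on this change. The step of a 1.5-fold lower number from compound 1 to compound 2 (0.16 log units; within the scatter) swapped the group on the same aromatic carbon, and a 1.9-fold higher number from compound 1 to compound 3 (0.29 log units; within the scatter) exchanged the whole aryl group; only a 2.8-fold higher number from compound 2 to compound 3 (0.45 log units; beyond the scatter) crossed the scatter, and modestly. Since a 1.5-fold lower number from compound 1 to compound 2 (0.16 log units; within the scatter) and a 1.9-fold higher number from compound 1 to compound 3 (0.29 log units; within the scatter) both stayed within the scatter, compound 4 is expected to show a 1.0-fold lower number from compound 1 to compound 4 (0.01 log units; within the scatter). Compound 4 is therefore estimated at 7000 nM, with a range from 3500 nM to 14000 nM.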

Compound 4, half-maximal inhibitory concentration: 11900 nM
Compound 4: the middle estimate sits 1.7-fold (0.23 log units) below what was measured; the measured number falls inside the stated range.
By their numbers in this assay, from the lowest: compounds 2, 1, 4 and 3 (each within the scatter of the next, the first and the last beyond it).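

In this assay, methyl in place of ethoxy on this aromatic carbon, para to a large group, comes with a 1.6-fold higher number from compound 1 to compound 4 (0.22 log units; within the scatter), so these two groups are not told apart here. Methyl in place of chloro on the same carbon, with a 2.4-fold higher number from compound 2 to compound 4 (0.38 log units; beyond the scatter), is the first step at this carbon to pass the scatter, though modestly. 4-Methylphenyl in place of 2-methylphenyl, with a 1.2-fold lower number from compound 3 to compound 4 (0.07 log units; within the scatter), does not separate the two placements of the methyl.

Nothing shown accounts for these steps. Going by these compounds, how an amine, a carboxylic acid or a longer chain such as butoxy on this carbon would compare remains open.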